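From chloro to trifluoromethoxy on the shared core

The source may report more compounds than this note shows. Statements on the series, on what has been measured and on what is new or still open speak of the compounds shown alone.

Values in a functional assay on MCF7 cells (Homo sapiens) for antiproliferative activity, read by MTT assay, with a stated time of 72 h; a lower number here means a stronger inhibitor, a higher number a weaker inhibitor:
Compound 1 `COc1cc(-n2ncnc2-c2ccc(C)cc2)cc(OC)c1OC`: 540 nM
Compound 2 `COc1ccc(-c2ncnn2-c2cc(OC)c(OC)c(OC)c2)cc1`: 360 nM
Compound 3 `COc1cc(-n2ncnc2-c2ccc(Cl)cc2)cc(OC)c1OC`: > 10000 nM

Compound 3 stands at the limit of > 10000 nM in this assay, at which 1 of the 3 values shown sits, so its entry is a limit and not a number.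

Compound 4 `COc1cc(-n2ncnc2-c2ccc(OC(F)(F)F)cc2)cc(OC)c1OC` differs from compound 3 at one place: trifluoromethoxy in place of chloro on an aromatic carbon. Trifluoromethoxy replaces chloro on an aromatic carbon, para to a large group.

Among the measured compounds shown here, three measured steps concern this same place. Methoxy in place of methyl gave a 1.5-fold lower number from compound 1 to compound 2 (0.18 log units; within the scatter). Chloro in place of methyl gave an at least 18-fold higher number from compound 1 to compound 3 (1.26 log units; beyond the scatter), a large step, and chloro in place of methoxy gave an at least 27-fold higher number from compound 2 to compound 3 (1.44 log units; beyond the scatter), also large.

None of these steps involves trifluoromethoxy, so the forecast is loose. Leaving chloro should bring a lower number in this assay, but only a partial return towards compound 2 at 360 nM is expected. The expected change is an at least 3.3-fold lower number from compound 3 to compound 4 (0.52 log units; beyond the scatter). For compound 4 the estimated value is 3000 nM, with an expected range of 400 nM to 10000 nM.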

Compound 4, half-maximal inhibitory concentration: > 10000 nM
Compound 4: a limit, no number; the forecaster's own chance of this, stated with the estimate: 35%; middle value at least 3.3-fold (0.52 log units) from the limit.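

In this assay, the entry for compound 4 is a limit and not a number, and the entry for compound 3 is one too, so the step between them cannot be read: the limit of > 10000 nM in this assay, at which 2 of the 4 values shown sit.

Trifluoromethyl in place of the methyl on the oxygen of compound 2 is enough to give an at least 27-fold higher number from compound 2 to compound 4 (1.44 log units; beyond the scatter). Trifluoromethoxy in place of the methyl on the ring gives an at least 18-fold higher number from compound 1 to compound 4 (1.26 log units; beyond the scatter), so at this position compound 4 sides with compound 3 and not with the methyl and methoxy compounds.

As far as these compounds go, how weak compound 3 and compound 4 really are stays open. So does whether an amine, a hydroxyl or an ethoxy group here would side with methyl and methoxy or with chloro and trifluoromethoxy.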